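Removing the halogens from the piperazine aryl group

The source may hold more compounds than are shown below. What is called first, only, known or untested is meant among the compounds shown, and "the series" means these compounds.

Three compounds share one core and differ only in the group on an amine nitrogen in a ring. Compound 1 `CCCn1c(=O)[nH]c2nc(-c3ccc(S(=O)(=O)N4CCN(Cc5cccc(Br)c5)CC4)cc3)[nH]c2c1=O` gives 0.148 nM in an assay on CHO cells for displacement of a labelled ligand from adenosine receptor A2b (Homo sapiens), read by scintillation counting, with a stated time of 75 min, in the presence of a further agent that is not named here (a lower number here means a stronger inhibitor, a higher number a weaker inhibitor), compound 2 `CCCn1c(=O)[nH]c2nc(-c3ccc(S(=O)(=O)N4CCN(c5ccccc5Br)CC4)cc3)[nH]c2c1=O` gives 0.137 nM, and compound 3 `CCCn1c(=O)[nH]c2nc(-c3ccc(S(=O)(=O)N4CCN(Cc5ccc(Br)c(F)c5)CC4)cc3)[nH]c2c1=O` gives 0.473 nM. Compound 3 thus carries the highest number of the three, with steps beyond the scatter to both companions: a 3.2-fold higher number from compound 1 to compound 3 (0.50 log units; beyond the scatter) and a 3.5-fold higher number from compound 2 to compound 3 (0.54 log units; beyond the scatter).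

Compound 4 `CCCn1c(=O)[nH]c2nc(-c3ccc(S(=O)(=O)N4CCN(c5ccccc5)CC4)cc3)[nH]c2c1=O` is reached from compound 3 by one change: phenyl in place of 4-bromo-3-fluorobenzyl on an amine nitrogen in a ring. The step most relevant to it is a 3.5-fold higher number from compound 2 to compound 3 (0.54 log units; beyond the scatter), which shows that a bromophenyl bound directly to the ring nitrogen gave a distinctly lower number than the 4-bromo-3-fluorobenzyl. Among the measured compounds shown here, compound 4 also places an aryl group directly on that nitrogen, though without any bromine, and no measured pair tells what dropping the bromine does. Compound 4 is therefore expected to move toward the number of compound 2, by about a 2.4-fold lower number from compound 3 to compound 4 (0.37 log units; beyond the scatter). Compound 4 is estimated at 0.2 nM in this assay, within a range from 0.07 nM to 0.6 nM.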

Compound 4, inhibition constant: 0.643 nM
For compound 4 the middle estimate is 3.2-fold (0.51 log units) below the measured one; the measured number lies above the stated range.
By their numbers in this assay, from the lowest: compounds 2 and 1 (each within the scatter of the next); then compounds 3 and 4 (each within the scatter of the next).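

Among the compounds shown here, compound 4 gives the first pair that isolates the bromo group on the aryl ring: in this assay there is a 4.7-fold higher number from compound 2 to compound 4 (0.67 log units; beyond the scatter) with hydrogen in place of bromo on an aromatic carbon, so that bromine counts at this position. Placing an aryl group directly on the ring nitrogen therefore does not by itself give a low number, since a 1.4-fold higher number from compound 3 to compound 4 (0.13 log units; within the scatter) leaves compound 4 level with the benzyl compound. With a 4.3-fold higher number from compound 1 to compound 4 (0.64 log units; beyond the scatter) as well, compound 4 stands apart from the two bromo compounds with the lowest numbers, while compound 3, which also carries bromine, goes against any simple bromine rule.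

Nothing available explains these steps. From the compounds shown here alone, it remains open whether chloro, methoxy or an amine on that aromatic carbon would behave like bromo or like hydrogen, and what an unsubstituted benzyl would give.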